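The source may hold more compounds than are shown below. What is called first, only, known or untested is meant among the compounds shown, and "the series" means these compounds.

Among the compounds with values here, compound 2 `COc1ccc(/C=C2\CCC/C(=C\c3c(Cl)cccc3Cl)C2=O)cc1` gives 232000 nM in an ADME assay on Vero cells (Chlorocebus sabaeus) for inhibition (on this read-out lower numbers stand for higher toxicity in this test and higher numbers for lower toxicity in this test), the lowest of the two numbers so far; its nearest neighbour is compound 1 `COc1ccc(/C=C2\CCC/C(=C\c3ccc(Cl)cc3)C2=O)cc1`, which in this assay gives 401000 nM. Within the data shown here, the one measured step on this aryl group, a 1.7-fold lower number from compound 1 to compound 2 (0.24 log units; within the scatter), stays within the scatter, so the two compounds cannot be ordered on cytotoxicity.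

Compound 3 `COc1ccc(/C=C2\CCC/C(=C\c3ccccc3F)C2=O)cc1` differs from compound 2 by 2-fluorophenyl in place of 2,6-dichlorophenyl on a double-bonded chain carbon bound to a double-bonded ring carbon. Among the measured compounds shown here, only the step from compound 1 to compound 2 bears on it, since it also swaps halogens on the same aryl ring, and that step was within the scatter. No step beyond the scatter is therefore expected in this assay for compound 3; the estimated step is a 1.3-fold higher number from compound 2 to compound 3 (0.11 log units; within the scatter). Compound 3 is expected to give about 300000 nM in this assay, with a likely range from 120000 nM to 750000 nM.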

Compound 3, half-maximal cytotoxic concentration: 270000 nM
The estimate for compound 3 lay 1.1-fold (0.05 log units) above the measured number, within the range that was stated.
By their numbers in this assay, from the lowest: compounds 2, 3 and 1 (each within the scatter of the next).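

Across the double-bonded chain carbon bound to a double-bonded ring carbon, 2-fluorophenyl in place of 2,6-dichlorophenyl gives a 1.2-fold higher number from compound 2 to compound 3 (0.07 log units; within the scatter) in this assay, and 2-fluorophenyl in place of 4-chlorophenyl gives a 1.5-fold lower number from compound 1 to compound 3 (0.17 log units; within the scatter) in the same read-out. With these steps, all three pairs among compounds 1, 2 and 3 lie within the scatter, so this read-out does not separate the three halogenated aryl groups, whether the halogen is fluorine or chlorine and whether the ring carries one halogen or two. No available data account for these numbers.

The compounds shown leave open whether a non-halogen group at this place, such as an amine or a carboxylic acid on the aryl ring, would move the number beyond the scatter. They also leave open whether a change to the methoxyphenyl group on the other side of the shared core would do so.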